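Phenylsulfanyl for dichlorophenyl on the shared core

The source may hold more compounds than are shown below. What is called first, only, known or untested is meant among the compounds shown, and "the series" means these compounds.

Measured so far in a functional assay on Jurkat cells for inhibition of nuclear factor NF-kappa-B complex (Homo sapiens); a higher number here means a weaker inhibitor, a lower number a stronger inhibitor:
compound 1, `CCOC(=O)c1cnc(-c2ccccc2)nc1NN1C(=O)C=C(C)C1=O`: 100 nM
compound 2, `CCOC(=O)c1cnc(-c2ccc(C(F)(F)F)cc2)nc1NN1C(=O)C=C(C)C1=O`: 400 nM
compound 3, `CCOC(=O)c1cnc(-c2cc(Cl)cc(Cl)c2)nc1NN1C(=O)C=C(C)C1=O`: 300 nM

Compound 3 sits second highest of the three numbers in this assay, close to compound 2 and clearly above compound 1. Among the compounds with values here, the steps that bear on the next change are a 3.0-fold higher number from compound 1 to compound 3 (0.48 log units; beyond the scatter) and a 4.0-fold higher number from compound 1 to compound 2 (0.60 log units; beyond the scatter); both put substituents onto the phenyl of compound 1 and both raised the number modestly, while a 1.3-fold lower number from compound 2 to compound 3 (0.12 log units; within the scatter) stayed within the scatter.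

Compound 4, `CCOC(=O)c1cnc(Sc2ccccc2)nc1NN1C(=O)C=C(C)C1=O`, carries the change (phenylsulfanyl in place of 3,5-dichlorophenyl on an aromatic carbon). Within the data shown here, this removes the two chlorines and at the same time inserts a sulfur between the core and the ring, so no measured step covers it directly. As far as these compounds go, the unsubstituted ring argues for a move back toward compound 1; the new linker is untested. A modest decrease is therefore expected, with wide uncertainty, as a 1.5-fold lower number from compound 3 to compound 4 (0.18 log units; within the scatter). Compound 4 is estimated at 200 nM in this assay, between 60 nM and 700 nM.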

Compound 4, half-maximal inhibitory concentration: 1000 nM
Beside the measured number, compound 4's estimate is 5.0-fold (0.70 log units) below it; the measured number lies above the stated range.
By their numbers in this assay, from the lowest: compound 1; then compounds 3 and 2 (each within the scatter of the next); then compound 4.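

In this assay the phenylsulfanyl group, on the aromatic carbon between two ring nitrogen atoms, gives the highest number of the four compounds, with a 3.3-fold higher number from compound 3 to compound 4 (0.52 log units; beyond the scatter) and a 2.5-fold higher number from compound 2 to compound 4 (0.40 log units; beyond the scatter) both beyond the scatter. The cleanest reading is a 10-fold higher number from compound 1 to compound 4 (1.00 log units; beyond the scatter). In this step the ring stays unsubstituted and only the sulfur enters. At this position, then, the inserted sulfur raises the number further than either the trifluoromethyl of compound 2 or the two chlorines of compound 3 did on the directly attached ring.

Still open, as far as these compounds go, is whether this belongs to sulfur or to any bridging atom, which an ether oxygen, an amine or a methylene bridge to the same phenyl would test, as would chlorine on the ring of compound 4. Nothing available accounts for the rise in the number.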